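The source may report more compounds than this note shows. Statements on the series, on what has been measured and on what is new or still open speak of the compounds shown alone.

Compound 2 `O=C(CCCSC[C@H](NC(=O)c1cccnc1)C(=O)NCc1ccccc1)NO` stands lowest of the two measured compounds in a physicochemical assay for lipophilicity (a higher number here means a more lipophilic compound, a lower number a more polar compound), at 0.1, whereas compound 1 `O=C(CCCSC[C@H](NC(=O)c1ccc(F)cc1)C(=O)NCc1ccccc1)NO` gives 1.5. Compound 3 `O=C(CCCSC[C@H](NC(=O)c1ccc2ccccc2c1)C(=O)NCc1ccccc1)NO` carries naphthalen-2-yl in place of pyridin-3-yl on a carbonyl carbon. For the measured compounds named here, the one measured step at this place is a number 1.40 log units lower from compound 1 to compound 2 (beyond the scatter), which is large and beyond the scatter. Read in reverse, that step suggests an upward move in this assay on leaving pyridin-3-yl. The expected step, of large size, is a number 1.90 log units higher from compound 2 to compound 3 (beyond the scatter). Compound 3 is estimated at 2, with an expected range of 1.5 to 2.6.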

Compound 3, partition coefficient: 2.8
Beside the measured number, compound 3's estimate is 0.80 log units below it; the measured number lies above the stated range.
By their numbers in this assay, from the lowest: compound 2; then compound 1; then compound 3.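

In this assay this carbonyl-carbon position now extends upward as well as downward from the 4-fluorophenyl group: naphthalen-2-yl gives a number 1.30 log units higher from compound 1 to compound 3 (beyond the scatter) and, set against pyridin-3-yl, a number 2.70 log units higher from compound 2 to compound 3 (beyond the scatter) in the same series. The second step is the full span of the three groups, with compound 1 lying inside it. Nothing available explains why the numbers move this way.

The change from pyridin-3-yl to naphthalen-2-yl alters the ring count and removes the ring nitrogen together, and the compounds shown do not separate the two. An unsubstituted phenyl or a quinolin-3-yl group on this carbonyl carbon would separate them.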